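Ortho substituent on the aryl ether of the shared core

This account rests on a few compounds, and the source may have more. Where it says the series, first, only, none or still open, it means among the compounds named here.

Three compounds share a core in which a piperidine-linked aryl ether carries an ortho substituent. Compound 1 `O=C(NCCC1CC1)c1ccc(N2CCC(Oc3ccccc3C(F)(F)F)CC2)nn1` gives 14 nM in an assay on microsomes from liver for inhibition of acyl-CoA desaturase 1 (Rattus norvegicus); on this read-out higher numbers stand for weaker inhibition and lower numbers for stronger inhibition. Compound 2 `Cc1ccccc1OC1CCN(c2ccc(-n3ccnc3)nn2)CC1` gives 39 nM in this assay, and compound 3 `c1cc2c(c(OC3CCN(c4ccc(-n5ccnc5)nn4)CC3)c1)CCC2` gives 10 nM. Going by the values given here, the value of compound 1 lies within the scatter of that of compound 3, whereas compound 2 sits beyond the scatter above it: the only measured single-point step is a 3.9-fold lower number from compound 2 to compound 3 (0.59 log units; beyond the scatter).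

Compound 4 `CC(=O)c1ccccc1OC1CCN(c2ccc(-n3ccnc3)nn2)CC1` is not yet measured. It differs from compound 3 by 2-acetylphenyl in place of 2,3-dihydro-1H-inden-4-yl on an oxygen on a saturated carbon. Among the compounds with values here, the one step that bears on this change is the exchange of the same position between compound 2 and compound 3, which gave a 3.9-fold lower number from compound 2 to compound 3 (0.59 log units; beyond the scatter); it shows that the group at this oxygen can move the number by a modest amount. Within the data shown here, no measured pair compares an acetyl with a methyl or with the fused five-membered ring, so the direction for compound 4 rests on the fact that the open phenyl of compound 2 gave the higher number 39 nM. Compound 4 is therefore expected to give a somewhat higher number than compound 3, a step of a 2.5-fold higher number from compound 3 to compound 4 (0.40 log units; beyond the scatter), with 25 nM expected and a range from 8 nM to 80 nM.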

Compound 4, half-maximal inhibitory concentration: 34 nM
Compound 4: middle estimate off by 1.4-fold (0.13 log units), on the low side, and the stated range covers the measured number.
By their numbers in this assay, from the lowest: compounds 3 and 1 (each within the scatter of the next); then compounds 4 and 2 (each within the scatter of the next).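

In this assay, 2-acetylphenyl in place of 2,3-dihydro-1H-inden-4-yl on the oxygen gives a 3.4-fold higher number from compound 3 to compound 4 (0.53 log units; beyond the scatter), so the lower number of compound 3 is now set against two different open phenyl groups rather than one. Acetyl in place of methyl on an aromatic carbon gives a 1.1-fold lower number from compound 2 to compound 4 (0.06 log units; within the scatter), which lies within the scatter: this assay does not separate these two groups, even though 2-acetylphenyl brings a carbonyl and a hydrogen-bond acceptor. Among compounds 2, 3 and 4, therefore, only compound 3 stands apart, and no measurement shown here explains why.

As far as these compounds go, it remains open whether an amine, a carboxylic acid or a longer chain such as propyl in place of the acetyl would also leave the number within the scatter of compound 4, or would move it. From the compounds shown here alone, it is also open whether 2,3-dihydro-1H-inden-4-yl would lower the number on the core of compound 1 as it does on the core of compound 2, since the trifluoromethyl compound differs from the others in more than one place.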